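A few compounds are considered here, and "the series" means these few. Any claim that something is new, unique, unknown or untested is made for them only; others in the source may bear on it.

Compound 3 `COc1cc(/C=C/C(=O)C2=C(/C=C/c3ccc(O)c(OC)c3)NC(=O)NC2c2ccccc2O)ccc1O`: 33.6%
Compound 2 `COc1cc(/C=C/C(=O)C2=C(/C=C/c3ccc(O)c(OC)c3)NC(=O)NC2c2ccc(C)cc2)ccc1O`: 17.2%
Compound 1 `COc1cc(/C=C/C(=O)C2=C(/C=C/c3ccc(O)c(OC)c3)NC(=O)NC2c2ccccc2)ccc1O`: 15.2%

In a functional assay, with a stated time of 20 min, tested at 2 uM (a higher number here means a stronger effect of the compound at the concentration tested, a lower number a weaker effect), compound 3 stands highest of the three, beyond the scatter from both others: the nearest is compound 2, with a number 16.4 percentage points higher from compound 2 to compound 3 (beyond the scatter), and the furthest is compound 1, with a number 18.4 percentage points higher from compound 1 to compound 3 (beyond the scatter). Compound 4 `COc1cc(/C=C/C(=O)C2=C(/C=C/c3ccc(O)c(OC)c3)NC(=O)NC2c2ccc(O)cc2)ccc1O` differs from compound 3 by 4-hydroxyphenyl in place of 2-hydroxyphenyl on a saturated ring carbon. Among the compounds with values here, two measured steps bear on it: the modest rise from the hydroxy added in a number 18.4 percentage points higher from compound 1 to compound 3 (beyond the scatter), and a number 16.4 percentage points higher from compound 2 to compound 3 (beyond the scatter), in which the same 2-hydroxyphenyl arrived. Within the data shown here, no step shows the hydroxy at the 4-position of that phenyl, so the gain of compound 3 may not carry over. Compound 4 is therefore expected to fall, with a step of a number 10.6 percentage points lower from compound 3 to compound 4 (beyond the scatter). Compound 4 is estimated at 23%, in the range 13% to 34%.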

Compound 4, a percentage reported as activity, at one concentration (the size of the read-out at that concentration, not a potency): 25%
Beside the measured number, compound 4's estimate is 2 percentage points below it; the range from low to high includes it.
By their numbers in this assay, from the lowest: compounds 1, 2, 4 and 3 (each within the scatter of the next, the first and the last beyond it).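

In this assay, 4-hydroxyphenyl in place of 2-hydroxyphenyl on the saturated ring carbon gives a number 8.6 percentage points lower from compound 3 to compound 4 (within the scatter), so these two placements of the hydroxy cannot be told apart. Compound 4 also cannot be separated from the compounds lacking a hydroxy on this phenyl: the steps are a number 9.8 percentage points higher from compound 1 to compound 4 (within the scatter) and a number 7.8 percentage points higher from compound 2 to compound 4 (within the scatter). Nothing available here explains these numbers. From the compounds shown here alone, whether an amine or a carboxylic acid at the 4-position of this phenyl would stand beyond the scatter from compound 1 remains open.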